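A few compounds are considered here, and "the series" means these few. Any claim that something is new, unique, unknown or untested is made for them only; others in the source may bear on it.

Compound 1 `CO[C@H]1O[C@H](COc2ccc3c(c2)CCCC3)[C@@H](O)[C@H](O)[C@H]1Oc1ccc(OC2CCCCC2)cc1` gives 20000 nM in a functional assay on MDA-MB-231 cells (Homo sapiens) for cytotoxicity, read by MTT assay, with a stated time of 48 h; on this read-out lower numbers stand for an effect already at smaller amounts and higher numbers for an effect only at larger amounts of compound.
Compound 3 `CO[C@@H]1O[C@H](COc2ccc(OC3CCCCC3)cc2)[C@@H](O)[C@H](O)[C@H]1Oc1ccc(OC2CCCCC2)cc1` gives 26000 nM in this assay.
Compound 2 `CO[C@@H]1O[C@H](COc2ccc3c(c2)CCCC3)[C@@H](O)[C@H](O)[C@H]1Oc1ccc(OC2CCCCC2)cc1` gives "not determined" (no result reported) in this assay, so no result is reported for it.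

Among the two numbers that exist, compound 1 carries the lower one, with compound 3 as its nearest neighbour; the gap between them lies within the usual scatter, so the two values are read as alike and no order is claimed between them. Compound 2 has no result in this assay; it is worth noting (the fact that compounds 1 and 2 differ only in the configuration as drawn), which is all that separates it from compound 1.

Compound 4 `CO[C@H]1O[C@H](COc2cccc(C(C)C)c2)[C@@H](O)[C@H](O)[C@H]1Oc1ccc(OC2CCCCC2)cc1` has not yet been measured in this assay. Set against compound 1, the change is 3-isopropylphenyl in place of 1,2,3,4-tetrahydronaphthalen-6-yl on an oxygen on a saturated carbon. For the measured compounds named here, no measured pair shows what such a swap does here, and the two measured values of the series sit close together. On that footing, the expected step is a 1.1-fold higher number from compound 1 to compound 4 (0.04 log units; within the scatter), which is no step beyond the scatter in either direction. Compound 4 is therefore expected to give 22000 nM in this assay, with a range from 8000 nM to 60000 nM, the wide span reflecting that this expectation rests on two close values and an untested change.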

Compound 4, half-maximal effective concentration: 38000 nM
The estimate for compound 4 lay 1.7-fold (0.24 log units) below the measured number; the measured number falls inside the stated range.
By their numbers in this assay, from the lowest: compounds 1, 3 and 4 (each within the scatter of the next).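

For the compounds shown here, the exchange of 1,2,3,4-tetrahydronaphthalen-6-yl for 3-isopropylphenyl on an oxygen on a saturated carbon gives the first step that can be read at this position in this assay, and it amounts to a 1.9-fold higher number from compound 1 to compound 4 (0.28 log units; within the scatter), so the two groups cannot be told apart on this read-out. The six-membered non-aromatic ring of carbon only, present in the group that leaves and absent from the one that enters, can therefore be given up here for 3-isopropylphenyl without a change beyond the scatter, although this single pair shows this for no other group at this position. Nothing known about these compounds accounts for the size of this step.

Going by these compounds, the groups compared at this position are both made of carbon only, so it remains open whether a group carrying an amine or a carboxylic acid on the same oxygen would shift the number beyond the scatter. Also open, on these data alone, is whether the same exchange would give a similar step in the other configuration as drawn at the core, and whether any group here can reach much lower numbers in this assay.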